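The source may report more compounds than this note shows. Statements on the series, on what has been measured and on what is new or still open speak of the compounds shown alone.

Measured so far in a functional assay on U-87MG ATCC cells for antiproliferative activity against U-87 MG (Homo sapiens), read by MTT assay, with a stated time of 48 h, tested at 10 uM; a lower number here means a stronger effect, a higher number a weaker effect of the compound at the concentration tested:
- compound 1 `COc1ccc(-c2nc(SCC(=O)c3sc(-c4ccccc4)nc3C)nc(N)c2C#N)cc1`: 60.8%
- compound 2 `COc1ccc(-c2nc(C)c(C(=O)CSc3nc(N)c(C#N)c(-c4ccc(Cl)cc4)n3)s2)cc1`: 44%
- compound 3 `COc1ccc(-c2nc(C)c(C(=O)CSc3nc(N)c(C#N)c(-c4ccccc4)n3)s2)cc1`: 57.8%

Among these three, compound 2 stands lowest in this assay, and both of its gaps to the others lie beyond the scatter. Within the data shown here, the only single-place step among the measured compounds, a number 13.8 percentage points higher from compound 2 to compound 3 (beyond the scatter), concerns a chloro on the aromatic ring attached to the shared core, not the part of the molecule now in question.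

Compound 4 `Cc1nc(-c2ccccc2)sc1C(=O)CSc1nc(N)c(C#N)c(-c2ccc(Cl)cc2)n1` differs from compound 2 in one place: hydrogen in place of methoxy on an aromatic carbon. Among the measured compounds shown here, no measured pair shows this particular change, so the step from compound 2 to compound 3 is the only guide, and it bears on it only loosely, as a removal of a group from a different aromatic ring. That step raised the number by a modest amount. A comparable or smaller move in this assay, upward or within the scatter, is therefore expected for compound 4, with the direction uncertain.

On this basis compound 4 is expected to give 51% in this assay, within a range of 36% to 66%, which means an estimated step of a number 7 percentage points higher from compound 2 to compound 4 (within the scatter).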

Compound 4, a percentage reported as activity, at one concentration (the size of the read-out at that concentration, not a potency): 58.8%
Estimate against measurement, compound 4: 7.8 percentage points below; measured number inside the range.
By their numbers in this assay, from the lowest: compound 2; then compounds 3, 4 and 1 (each within the scatter of the next).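

In this assay the change from 4-methoxyphenyl to phenyl gives a number 14.8 percentage points higher from compound 2 to compound 4 (beyond the scatter) and thus shows that this methoxy counts, as the chloro on the other aromatic ring already did. Only compound 2 carries both this methoxy and that chloro, and it alone stands apart from the other three compounds. With phenyl in the place studied here, chloro in place of methoxy on the other ring gives a number 2 percentage points lower from compound 1 to compound 4 (within the scatter) and so does not separate those two groups.

Still open, going by these compounds, is whether a hydroxyl, an amine or a longer ether chain in place of this methoxy would keep the lower number of compound 2, and what hydrogen in both places would give. Nothing on hand offers a reason for either step.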